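The source may report more compounds than this note shows. Statements on the series, on what has been measured and on what is new or still open speak of the compounds shown alone.

Of the compounds shown here, three sharing one core have been tested in a functional assay on ECa-109 cells for inhibition, with ECa-109 cell line (Homo sapiens) as the target, read by sulforhodamine B assay; on this read-out higher numbers stand for weaker inhibition and lower numbers for stronger inhibition. Compound 1 `O=C1C(Nc2ccccc2F)=CC(=O)c2c1nc1n2[C@H]2OC[C@@H](O)[C@H]2OC1` carries a (2-fluorophenyl)amino group, and in this assay compound 1 gives 2660 nM. Compound 2 `O=C1C=C(Nc2ccc(Br)cc2)C(=O)c2c1nc1n2[C@H]2OC[C@@H](O)[C@H]2OC1`, which carries a bromo group on its aromatic ring, gives 2850 nM, a gap within the scatter, so compound 1 stands at the lower of the two plain numbers by a margin that means nothing. Compound 3 `COc1ccc(NC2=CC(=O)c3nc4n(c3C2=O)[C@H]2OC[C@@H](O)[C@H]2OC4)cc1` has a methoxy group in place of that bromo, and for compound 3 this assay reports only a limit, > 4000 nM. That is the limit of > 4000 nM in this assay, at which 1 of the 3 values shown sits. Among the measured compounds shown here, the same change is the one measured step: an at least 1.4-fold higher number from compound 2 to compound 3 (0.14 log units; that floor lies within the scatter).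

Compound 4 `COc1cccc(NC2=CC(=O)c3c(nc4n3[C@H]3OC[C@@H](O)[C@H]3OC4)C2=O)c1` differs from compound 1 by 3-methoxyphenyl in place of 2-fluorophenyl on an amine nitrogen. For the measured compounds named here, no measured step pairs these two groups directly; the one step that brings in a methoxy group points toward weaker inhibition, at least to the extent of its floor, and that is the only guide available. A step of about a 1.4-fold higher number from compound 1 to compound 4 (0.15 log units; within the scatter) is therefore expected, toward weaker inhibition, with a real chance that only a limit is reported. Compound 4 is estimated at 3800 nM, between 1900 nM and 8000 nM.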

Compound 4, half-maximal inhibitory concentration: 3340 nM
The estimate for compound 4 lay 1.1-fold (0.06 log units) above the measured number; measured number inside the range.
By their numbers in this assay, from the lowest: compounds 1, 2 and 4 (each within the scatter of the next). At a limit, above all of these: compound 3.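

Among the compounds shown here, compound 4 is the first measured change made directly on the aryl group of compound 1, and in this assay it gives a 1.3-fold higher number from compound 1 to compound 4 (0.10 log units; within the scatter). So on this amine nitrogen, 3-methoxyphenyl and 2-fluorophenyl cannot be told apart by this read-out: exchanging one for the other, with the shared core left unchanged, moves the number by no more than repeated measurements would. Compound 3 remains the only compound reported as a limit, and compound 4 adds a plain number rather than a second limit: the limit of > 4000 nM in this assay, at which 1 of the 4 values shown sits.

This single step changes both the group on the ring and its place on the ring, so it cannot say which of the two matters, or whether either does; 3-fluorophenyl and 2-methoxyphenyl would separate them. The compounds shown also leave open what happens with an unsubstituted phenyl, a pyridine ring or a short alkyl chain on this nitrogen, and with a ring carrying an amine or a carboxylic acid.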